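An Isobutyl Group Added to Two Related Cores

This account rests on a few compounds, and the source may have more. Where it says the series, first, only, none or still open, it means among the compounds named here.

Measured so far:
- compound 1, `Cc1ccc(S(=O)(=O)N2CCC(Cl)CC2)cc1` — > 100000 nM
- compound 2, `Cc1ccc(S(=O)(=O)N2CC[C@@H](Cl)C[C@@H]2CC(C)C)cc1` — 19000 nM
- compound 3, `Cc1ccc(S(=O)(=O)N2CC=C(Cl)CC2)cc1` — > 100000 nM

In a functional assay on SW1573 cells (Homo sapiens) for antiproliferative activity, read by sulforhodamine B assay, with a stated time of 48 h (on this read-out higher numbers stand for weaker inhibition of growth and lower numbers for stronger inhibition of growth), compound 1 reaches only a limit of the assay, > 100000 nM, not a number. Compound 2 gives 19000 nM in this assay. The change between them is isobutyl in place of hydrogen on a saturated ring carbon, and it brought an at least 5.2-fold lower number from compound 1 to compound 2 (0.72 log units; beyond the scatter); how far beyond that the true step goes is hidden, because of the limit of > 100000 nM in this assay, at which 2 of the 3 values shown sit.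

Compound 3 also sits at a limit of this assay, > 100000 nM. Its core and the core of compound 1 differ in a way that is not broken down here. The unmeasured compound 4, `Cc1ccc(S(=O)(=O)N2CCC(Cl)=CC2CC(C)C)cc1`, arises from compound 3 by isobutyl in place of hydrogen on a saturated ring carbon, the same change that turned compound 1 into compound 2, made in the same kind of place.

For compound 4 the step of an at least 4.0-fold lower number from compound 3 to compound 4 (0.60 log units; beyond the scatter) is expected, resting on compound 1 to compound 2 having shown an at least 5.2-fold lower number from compound 1 to compound 2 (0.72 log units; beyond the scatter). Compound 4 is thus estimated at 25000 nM, with a plausible range from 8000 nM to 100000 nM.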

Compound 4, concentration for 50% growth inhibition: 31000 nM
For compound 4 the middle estimate is 1.2-fold (0.09 log units) below the measured one; the range from low to high includes it.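

In this assay, isobutyl in place of hydrogen on a saturated ring carbon brought an at least 3.2-fold lower number from compound 3 to compound 4 (0.50 log units; beyond the scatter), so on the second core the change again moved the number the same way, towards stronger inhibition of growth. Set beside the earlier case, the two steps read as follows: the same change on two cores in this assay, an at least 5.2-fold lower number (0.72 log units; beyond the scatter) from compound 1 to compound 2 and an at least 3.2-fold lower number (0.50 log units; beyond the scatter) from compound 3 to compound 4; the limit leaves it open whether they differ. For the compounds shown here, this is a result from only two pairs, so it supports carrying the change between these two cores but gives no general rule, and the full size of each step stays hidden because compound 1 and compound 3 both sit at a limit rather than at a number: the limit of > 100000 nM in this assay, at which 2 of the 4 values shown sit.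

The compounds shown leave open whether a methyl group, a longer chain, an amine or a carboxylic acid on that same ring carbon would lower the number as isobutyl does. They also leave open how either core would respond if a fluoro group stood in place of the chloro group.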